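The source may report more compounds than this note shows. Statements on the series, on what has been measured and on what is new or still open speak of the compounds shown alone.

Measured compounds: compound 1 `CCCC(=O)C1=C(C)NC(=O)NC1c1ccoc1`, compound 2 `CC1=C(C(N)=O)C(c2ccoc2)NC(=O)N1`, compound 3 `CC1=C(C(=O)OC2CCCCC2)C(c2ccco2)NC(=O)N1`.

In an assay on membranes from HeLa cells for displacement of a labelled ligand from adenosine receptor A3 (Homo sapiens), read by scintillation counting, with a stated time of 180 min, tested at 1 uM (on this read-out lower numbers stand for less inhibition and higher numbers for more inhibition at the one concentration tested (going by the name of the read-out)), compound 1 gives 2%. Compound 2 gives 2%, and compound 3 gives 4%. Compound 3 holds the highest of the three numbers, yet its gaps to compound 1 and to compound 2 both lie within the scatter, so the three read alike. For the measured compounds named here, the only step between measured compounds, no change at the digits printed from compound 1 to compound 2 (within the scatter), concerns a group on a carbonyl carbon, not the furan-3-yl. Compound 4 `CC1=C(C(=O)OC2CCCCC2)C(c2ccoc2)NC(=O)N1` differs from compound 3 by furan-3-yl in place of furan-2-yl on a saturated ring carbon. Going by the values given here, no measured step bears on this change, so nothing beyond the scatter is expected. The step from compound 3 to compound 4 is estimated as a number 1 percentage points lower from compound 3 to compound 4 (within the scatter). Compound 4 is expected to give 3%, between 0% and 12%.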

Compound 4, a percentage reported as inhibition, at one concentration (the size of the read-out at that concentration, not a potency): 1%
Estimate against measurement, compound 4: 2 percentage points above; low and high end bracket the measured number.
By their numbers in this assay, from the lowest: compounds 4, 1, 2 and 3 (each within the scatter of the next).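

In this assay, for the compounds shown here, the first reading of this change, furan-3-yl in place of furan-2-yl on a saturated ring carbon, is a number 3 percentage points lower from compound 3 to compound 4 (within the scatter) and so shows no effect that can be told from the scatter. With cyclohexyloxy in place of amino on the carbonyl carbon the result is a number 1 percentage points lower from compound 2 to compound 4 (within the scatter) and with cyclohexyloxy in place of propyl it is a number 1 percentage points lower from compound 1 to compound 4 (within the scatter) so these swaps also leave the read-out unmoved. Nothing measured here offers an explanation for these readings.

From the compounds shown here alone, whether a phenyl ring in place of the furan, or a longer chain such as hexyl on the carbonyl carbon, would move the number beyond the scatter remains open.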